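A few compounds are considered here, and "the series" means these few. Any claim that something is new, unique, unknown or untested is made for them only; others in the source may bear on it.

Compound 1 `CCC(CNC(=O)c1ccc2c(c1)c(Cc1ccc(C(=O)NS(=O)(=O)c3ccccc3C)cc1OC)cn2C)CC(F)(F)F`: 6.45
Compound 2 `COc1cc(C(=O)O)ccc1Cc1cn(C)c2ccc(C(=O)NCC(C)CC(F)(F)F)cc12`: 5.12
Compound 3 `CCC(C)CNC(=O)c1ccc2c(c1)c(Cc1ccc(C(=O)NS(=O)(=O)c3ccccc3C)cc1OC)cn2C`: 5.85

In a physicochemical assay for lipophilicity (a higher number here means a more lipophilic compound, a lower number a more polar compound), compound 3 stands second highest of the three; its nearest neighbour is compound 1, a number 0.60 log units lower from compound 1 to compound 3 (beyond the scatter), and compound 2 lies furthest from it. Compound 4 `CCC(C)CNC(=O)c1ccc2c(c1)c(Cc1ccc(C(=O)O)cc1OC)cn2C` differs from compound 3 in one place: hydroxy in place of ((2-methylphenyl)sulfonyl)amino on a carbonyl carbon. For the measured compounds named here, no measured step covers this change directly, but compounds 1 and 2, which share compound 4's acid group and compound 3's sulfonyl group with further changes on the chain, show a gap of over one unit in this assay. Compound 4 is therefore expected to drop well beyond the scatter, with a number 1.35 log units lower from compound 3 to compound 4 (beyond the scatter). Compound 4 is estimated at 4.5, within 3.9 to 5.1.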

Compound 4, partition coefficient: 4.86
Beside the measured number, compound 4's estimate is 0.36 log units below it; low and high end bracket the measured number.
By their numbers in this assay, from the lowest: compounds 4 and 2 (each within the scatter of the next); then compound 3; then compound 1.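

With the chain unchanged, this assay now isolates the exchange of ((2-methylphenyl)sulfonyl)amino for hydroxy on a carbonyl carbon: a number 0.99 log units lower from compound 3 to compound 4 (beyond the scatter). With hydroxy on that carbon, methyl in place of trifluoromethyl on the chain gives a number 0.26 log units lower from compound 2 to compound 4 (within the scatter), whereas with the sulfonyl group, hydrogen in place of trifluoromethyl gives a number 0.60 log units lower from compound 1 to compound 3 (beyond the scatter). Nothing available explains these steps. The compounds shown leave open how a methylsulfonylamino group or a simple primary amide would read on this carbonyl carbon. They also leave open whether a longer chain would shift these numbers.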